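From 4-Ethylphenyl to Cyclopentyl on the Amine Nitrogen

This account rests on a few compounds, and the source may have more. Where it says the series, first, only, none or still open, it means among the compounds named here.

Among the compounds with values here, in a functional assay on ECa-109 cells for inhibition, with ECa-109 cell line (Homo sapiens) as the target, read by sulforhodamine B assay (on this read-out higher numbers stand for weaker inhibition and lower numbers for stronger inhibition), compound 2 `CCc1ccc(NC2=CC(=O)c3nc4n(c3C2=O)[C@H]2OC[C@@H](O)[C@H]2OC4)cc1` gives 3080 nM, the only true number so far. Compound 1 `O=C1C=C(NC2CCCCC2)C(=O)c2c1nc1n2[C@H]2OC[C@@H](O)[C@H]2OC1` reads > 16000 nM, which is a limit of this assay and not a number. Compound 3 `O=C1C=C(NC2CCCC2)C(=O)c2c1nc1n2[C@H]2OC[C@@H](O)[C@H]2OC1` has cyclopentyl in place of 4-ethylphenyl on an amine nitrogen. It therefore gives up the six-membered aromatic ring for a five-membered non-aromatic ring of carbon, much as cyclohexyl stands in compound 1. Within the data shown here, the one measured step that bears on this change is an at least 5.1-fold lower number from compound 1 to compound 2 (0.71 log units; beyond the scatter), which ran from cyclohexyl to 4-ethylphenyl. Read in reverse, that step suggests a change of comparable size toward weaker inhibition, beyond the scatter. The expected change is a 4.5-fold higher number from compound 2 to compound 3 (0.66 log units; beyond the scatter). For compound 3 the estimated value is 14000 nM, with an expected range from 5500 nM to 36000 nM.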

Compound 3, half-maximal inhibitory concentration: > 16000 nM
Compound 3 gave a limit, no number (the forecaster's own chance of this, stated with the estimate: 55%); at least 1.1-fold (0.05 log units) between middle value and limit.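

Moving to cyclopentyl gives an at least 5.1-fold higher number from compound 2 to compound 3 (0.71 log units; beyond the scatter), so the weaker inhibition seen with cyclohexyl in compound 1 is not confined to that one ring. Within the data shown here, on this amine nitrogen, both non-aromatic carbon rings now stand apart from the 4-ethylphenyl of compound 2, the only one of the three compounds with a true number in this assay. The step from compound 1 to compound 3 cannot be read, and neither ring size can be ranked over the other, as both values rest on the same limit: the limit of > 16000 nM in this assay, at which 2 of the 3 values shown sit.

As far as these compounds go, it remains open whether the aromatic ring alone is enough or whether the ethyl group on it also matters, which a plain phenyl on this nitrogen would address. From the compounds shown here alone, how a benzyl group, with its ring set one carbon further out, would read also remains open.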